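Compound 3: a difluorophenyl swap on two inactive limits

This account rests on a few compounds, and the source may have more. Where it says the series, first, only, none or still open, it means among the compounds named here.

Measured in a functional assay on NALM-6 cells (Homo sapiens) for cytotoxicity, with a stated time of 72 h; a lower number here means that less compound is needed, a higher number that more compound is needed for the effect:
- compound 1 `C=C[C@@](C)(/C=C/c1ccc(OCc2ccccc2)cc1)CCC=C(C)C`: > 43400 nM
- compound 2 `C=C[C@@](C)(/C=C/c1ccc(Nc2ccc(OC)cc2)cc1)CCC=C(C)C`: > 43400 nM

Both entries are limits of the assay and not numbers. Compound 2 stands at a limit, > 43400 nM, with no number behind it. Its place is not unique in the series, as the record so far shows (the limit of > 43400 nM in this assay, at which 2 of the 2 values shown sit).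

Compound 3 `C=C[C@@](C)(/C=C/c1ccc(Nc2ccc(F)c(F)c2)cc1)CCC=C(C)C` differs from compound 2 by 3,4-difluorophenyl in place of 4-methoxyphenyl on a nitrogen on an aromatic ring. The shared core and the rest of the molecule stay the same.

Among the compounds with values here, the only measured step is a step that the two limits leave unreadable from compound 1 to compound 2, with (4-methoxyphenyl)amino in place of benzyloxy on an aromatic carbon. It changes a different place in the structure and gives no size to carry over. Within the data shown here, no measured compound in this assay yet has a number, so the expectation rests on the shared limit (the limit of > 43400 nM in this assay, at which 2 of the 2 values shown sit). Another limit is the likeliest report, and any number would point towards less compound being needed. The step expected is an at least 1.2-fold lower number from compound 2 to compound 3 (0.09 log units; that floor lies within the scatter). The expected value for compound 3 is 35000 nM, with an estimated range of 12000 nM to 60000 nM.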

Compound 3, half-maximal effective concentration: > 43400 nM
Compound 3 gave a limit, no number; the forecaster's own chance of this, stated with the estimate: 60%; at least 1.2-fold (0.09 log units) between middle value and limit.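

In this assay compound 3 gives > 43400 nM, a limit and not a number. No step among compound 1, compound 2 and compound 3 can be read, since all three sit at a limit: the limit of > 43400 nM in this assay, at which 3 of the 3 values shown sit.

The compounds shown leave open how large the effect of 3,4-difluorophenyl in place of 4-methoxyphenyl is in this assay, and whether any compound in the series reaches a number there.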